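This account rests on a few compounds, and the source may have more. Where it says the series, first, only, none or still open, it means among the compounds named here.

Measured compounds:
compound 1 `O=C(Nc1cccc(-n2cc(-c3ccncc3)c(-c3ccc(Cl)c(O)c3)n2)c1)Nc1cccc(C(F)(F)F)c1`, 1390 nM
compound 2 `COc1cc(-c2nn(-c3cccc(NC(=O)Nc4ccc(Cl)c(Cl)c4)c3)cc2-c2ccncc2)ccc1Cl`, 1210 nM
compound 3 `COc1cc(-c2nn(-c3cccc(NC(=O)Nc4cccc(C(F)(F)F)c4)c3)cc2-c2ccncc2)ccc1Cl`, 900 nM

In a functional assay on HCT-116 cells (Homo sapiens) for inhibition, read by sulforhodamine B assay, with a stated time of 48 h (a lower number here means a stronger inhibitor of growth, a higher number a weaker inhibitor of growth), compound 3 gives the lowest of the three numbers, but its nearest neighbour compound 2 sits only a 1.3-fold lower number from compound 2 to compound 3 (0.13 log units; within the scatter) away and compound 1 only a 1.5-fold lower number from compound 1 to compound 3 (0.19 log units; within the scatter) away, both within the scatter, so the three compounds cannot be ordered on these data. Compound 4 `COc1cc(-c2nn(-c3cccc(NC(=O)Nc4ccc(Cl)c(C(F)(F)F)c4)c3)cc2-c2ccncc2)ccc1Cl` differs from compound 3 by a single change: chloro in place of hydrogen on an aromatic carbon. Among the measured compounds shown here, no measured step adds a chloro at this place. The step from compound 2 to compound 3 concerns the same aryl group on the urea and shows that exchanging 3,4-dichlorophenyl for 3-(trifluoromethyl)phenyl moved the number by a 1.3-fold lower number from compound 2 to compound 3 (0.13 log units; within the scatter), within the scatter. The step from compound 1 to compound 3 lies elsewhere in the molecule and does not bear on this change. Compound 4 is therefore expected to stay close to compound 3, with a step of about a 1.1-fold lower number from compound 3 to compound 4 (0.05 log units; within the scatter) in this assay, not beyond the scatter. The estimate for compound 4 is 800 nM, within a range of 350 nM to 1800 nM.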

Compound 4, concentration for 50% growth inhibition: 1170 nM
The estimate for compound 4 lay 1.5-fold (0.17 log units) below the measured number; the measured number falls inside the stated range.
By their numbers in this assay, from the lowest: compounds 3, 4, 2 and 1 (each within the scatter of the next).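

In this assay, chloro in place of hydrogen on the aromatic carbon ortho to the trifluoromethyl group gave a 1.3-fold higher number from compound 3 to compound 4 (0.11 log units; within the scatter), so this first probe of that carbon shows that a chloro there leaves the number within the scatter. Trifluoromethyl in place of chloro on an aromatic carbon gave a 1.0-fold lower number from compound 2 to compound 4 (0.01 log units; within the scatter), so the 3,4-dichlorophenyl and 4-chloro-3-(trifluoromethyl)phenyl groups on the urea cannot be told apart in this assay. No measurement given here speaks to the reason for either result.

Still open, as far as these compounds go, is whether an amine or a carboxylic acid on this same carbon would also stay within the scatter. Also open, from the compounds shown here alone, is whether the chloro step would read the same on the core of compound 1, which carries a hydroxy group.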